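Fluoro to bromo on the benzamide ring of compound 2

This account rests on a few compounds, and the source may have more. Where it says the series, first, only, none or still open, it means among the compounds named here.

Measured compounds:
compound 1 `CC(=O)Nc1cccc(NC(=O)COc2ccc3c(=O)ccoc3c2)c1` gives 136 nM
compound 2 `O=C(COc1ccc2c(=O)ccoc2c1)Nc1cccc(NC(=O)c2ccc(F)cc2)c1` gives 54 nM

Both numbers come from an assay on isolated protein for inhibition of Rho-associated protein kinase 2 (Homo sapiens), read by scintillation counting, radiometric assay and 33P incorporation, with a stated time of 40 min, in the presence of a further agent that is not named here; a lower number here means a stronger inhibitor, a higher number a weaker inhibitor. Among the compounds with values here, compound 2 stands lowest of the two in this assay; its nearest neighbour is compound 1, and the only measured step, a 2.5-fold lower number from compound 1 to compound 2 (0.40 log units; beyond the scatter), is beyond the scatter.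

The next compound, compound 3 `O=C(COc1ccc2c(=O)ccoc2c1)Nc1cccc(NC(=O)c2ccc(Br)cc2)c1`, differs from compound 2 by bromo in place of fluoro on an aromatic carbon, para to a large group; the change is one halogen for another at the same position.

Within the data shown here, no measured step bears directly on this change. Among the measured compounds shown here, the single measured step concerns the carbonyl substituent as a whole and says nothing about exchanging one halogen for another on that ring. With no comparison of this kind in hand, the expectation for this assay is a step from compound 2 to compound 3 of about a 1.2-fold lower number from compound 2 to compound 3 (0.08 log units; within the scatter), not clearly beyond the scatter. Compound 3 is therefore estimated at 45 nM, with a range of 20 nM to 110 nM.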

Compound 3, half-maximal inhibitory concentration: 49 nM
Compound 3: middle estimate off by 1.1-fold (0.04 log units), on the low side; the range from low to high includes it.
By their numbers in this assay, from the lowest: compounds 3 and 2 (each within the scatter of the next); then compound 1.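

In this assay, within the data shown here, bromo in place of fluoro on an aromatic carbon, para to a large group, gives a 1.1-fold lower number from compound 2 to compound 3 (0.04 log units; within the scatter), so the two halogens cannot be told apart at this position, something the earlier compounds could not show because they held only one halogen. The earlier step covered the carbonyl substituent as a whole; with the other halogen, the same comparison with the methyl compound gives a 2.8-fold lower number from compound 1 to compound 3 (0.44 log units; beyond the scatter), so the advantage over the methyl compound is seen with both 4-fluorophenyl and 4-bromophenyl. Nothing in hand speaks to what lies behind these numbers.

Two halogens are too narrow a set to show whether this position tolerates change in general, and a methoxy group, a nitrile, an amine or a carboxylic acid in the same place could separate from them in either direction. Also open, on these data alone, is whether the same indifference to the halogen would hold with the substituent elsewhere on the ring, or with a longer chain in place of the direct link between the carbonyl and the ring.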